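Amide Aryl Swap on a Shared Core: Expected Inactivity

This account rests on a few compounds, and the source may have more. Where it says the series, first, only, none or still open, it means among the compounds named here.

Compound 1 `O=C(Nc1ccc(Cl)c(-c2nnc3c(Cl)cccn23)c1)c1ccc(C(F)(F)F)cc1Cl`: > 100000 nM
Compound 2 `CS(=O)(=O)c1ccc(C(=O)Nc2ccc(Cl)c(-c3nnc4c(Cl)cccn34)c2)cc1`: > 100000 nM

In a functional assay on MDA-MB-468 cells (Homo sapiens) for antiproliferative activity, read by MTT assay, with a stated time of 72 h (on this read-out lower numbers stand for stronger inhibition and higher numbers for weaker inhibition), compound 1 gives only a limit, > 100000 nM. In this assay compound 2 likewise gives only a limit, > 100000 nM. Going by the values given here, no step between measured compounds can be computed, and both values sit at the limit of > 100000 nM in this assay, at which 2 of the 2 values shown sit. Compound 3 `O=C(Nc1ccc(Cl)c(-c2nnc3c(Cl)cccn23)c1)c1ccc(Cl)cc1Cl` carries 2,4-dichlorophenyl in place of 4-(methylsulfonyl)phenyl on a carbonyl carbon. Among the compounds with values here, compound 2 stands at a limit, and no measured step guides the estimate. Compound 3 is expected to remain at that limit, with a step that the limit leaves unreadable from compound 2 to compound 3 amounting to no change beyond the scatter. Compound 3 is estimated at 150000 nM, between 50000 nM and 500000 nM.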

Compound 3, half-maximal inhibitory concentration: 21600 nM
Beside the measured number, compound 3's estimate is 6.9-fold (0.84 log units) above it, and the stated range ends above it.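

In this assay, 2,4-dichlorophenyl in place of 4-(methylsulfonyl)phenyl on a carbonyl carbon gives an at least 4.6-fold lower number from compound 2 to compound 3 (0.66 log units; beyond the scatter), and chloro in place of trifluoromethyl on an aromatic carbon gives an at least 4.6-fold lower number from compound 1 to compound 3 (0.66 log units; beyond the scatter). Compound 3 alone yields a number rather than a limit, so the phenyl group on this carbonyl carbon can move the read-out on the shared core. Compound 1 and compound 2 remain at a limit: the limit of > 100000 nM in this assay, at which 2 of the 3 values shown sit.

From the compounds shown here alone, both steps are minimum sizes, so their true sizes stay open. Also open, going by these compounds, is whether an amine or a carboxylic acid on this phenyl group would keep the gain.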